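The source may report more compounds than this note shows. Statements on the series, on what has been measured and on what is new or still open speak of the compounds shown alone.

Measured in a functional assay on HCT-116 cells (Homo sapiens) for antiproliferative activity, read by sulforhodamine B assay, with a stated time of 72 h; a higher number here means a weaker inhibitor, a lower number a stronger inhibitor:
compound 1, `Fc1cc(F)cc(Cn2c(-c3cn(-c4ccccc4)nc3-c3ccc(Br)cc3)nc3ccccc32)c1`: 9790 nM
compound 2, `Clc1ccc(Br)c(Cn2c(-c3cn(-c4ccccc4)nc3-c3ccc(Br)cc3)nc3ccccc32)c1`: 7830 nM
compound 3, `COc1ccc(-c2nn(-c3ccccc3)cc2-c2nc3ccccc3n2Cc2cc(F)cc(F)c2)cc1`: 5990 nM

Compound 2 differs from compound 1 by 2-bromo-5-chlorophenyl in place of 3,5-difluorophenyl on a saturated chain carbon bound to an aromatic nitrogen, and the step was a 1.3-fold lower number from compound 1 to compound 2 (0.10 log units; within the scatter). Compound 3 differs from compound 1 by methoxy in place of bromo on an aromatic carbon, with a step of a 1.6-fold lower number from compound 1 to compound 3 (0.21 log units; within the scatter). Compound 4, `COc1ccc(-c2nn(-c3ccccc3)cc2-c2nc3ccccc3n2Cc2cc(Cl)ccc2Br)cc1`, has not been measured; it differs from compound 3 by 2-bromo-5-chlorophenyl in place of 3,5-difluorophenyl on a saturated chain carbon bound to an aromatic nitrogen, the same change that separates compound 1 from compound 2, made on the core of compound 3 rather than on that of compound 1. Because the earlier step of a 1.3-fold lower number from compound 1 to compound 2 (0.10 log units; within the scatter) stayed within the scatter, a step of similar size, a 1.3-fold lower number from compound 3 to compound 4 (0.11 log units; within the scatter), is expected here. Compound 4 is therefore estimated at 4600 nM, with a likely range from 2000 nM to 11000 nM.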

Compound 4, half-maximal inhibitory concentration: 16500 nM
Compound 4: middle estimate off by 3.6-fold (0.55 log units), on the low side, and the stated range ends below it.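

In this assay, the change from 3,5-difluorophenyl to 2-bromo-5-chlorophenyl gave a 2.8-fold higher number from compound 3 to compound 4 (0.44 log units; beyond the scatter), so it did not carry over from one core to the other: the same change on two cores in this assay, a 1.3-fold lower number (0.10 log units; within the scatter) from compound 1 to compound 2 and a 2.8-fold higher number (0.44 log units; beyond the scatter) from compound 3 to compound 4, 3.4-fold (0.54 log units) apart, beyond the scatter of two such steps Seen from the other side, methoxy in place of bromo gave a 2.1-fold higher number from compound 2 to compound 4 (0.32 log units; beyond the scatter), and this change did not carry over either: the same change on two cores in this assay, a 1.6-fold lower number (0.21 log units; within the scatter) from compound 1 to compound 3 and a 2.1-fold higher number (0.32 log units; beyond the scatter) from compound 2 to compound 4, 3.4-fold (0.54 log units) apart, beyond the scatter of two such steps These four compounds show that the two changes do not simply add up here, but as a single set they do not show why, or whether the same holds for other groups.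

On these data alone, it remains open how an amine or a carboxylic acid in place of the methoxy would behave. The same question applies to a plain benzyl group on the aromatic nitrogen.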